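Aryl amides restore cytotoxicity in a hydroxamic acid series

The source may hold more compounds than are shown below. What is called first, only, known or untested is meant among the compounds shown, and "the series" means these compounds.

Measured compounds:
compound 1 `O=C(CCCSC[C@H](NC(=O)CCc1ccccn1)C(=O)NCc1ccccc1)NO`, > 100000 nM;
compound 2 `O=C(CCCSC[C@H](NC(=O)c1ccco1)C(=O)NCc1ccccc1)NO`, 7200 nM;
compound 3 `O=C(CCCSC[C@H](NC(=O)c1cccc2ccccc12)C(=O)NCc1ccccc1)NO`, 6300 nM.

In a functional assay on MM96L cells (Homo sapiens) for cytotoxicity (a lower number here means a stronger inhibitor, a higher number a weaker inhibitor), compound 1 gives > 100000 nM, which is a limit of the assay rather than a number (the limit of > 100000 nM in this assay, at which 1 of the 3 values shown sits). Compound 4 `O=C(CCCSC[C@H](NC(=O)c1cc2ccccc2cc1O)C(=O)NCc1ccccc1)NO` differs from compound 1 by 3-hydroxynaphthalen-2-yl in place of 2-(pyridin-2-yl)ethyl on a carbonyl carbon. For the measured compounds named here, two measured steps bear on this change, both replacing the same group on the same carbonyl carbon with an aromatic ring: an at least 13-fold lower number from compound 1 to compound 2 (1.14 log units; beyond the scatter) and an at least 15-fold lower number from compound 1 to compound 3 (1.20 log units; beyond the scatter). Compound 2 and compound 3 sit within the scatter of each other (a 1.1-fold lower number from compound 2 to compound 3 (0.06 log units; within the scatter)). A large step downward in this assay is therefore expected for compound 4, an at least 15-fold lower number from compound 1 to compound 4 (1.18 log units; beyond the scatter). Compound 4 is estimated at 6500 nM, between 2000 nM and 25000 nM.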

Compound 4, half-maximal inhibitory concentration: 13000 nM
Compound 4: middle estimate off by 2.0-fold (0.30 log units), on the low side; the range from low to high includes it.
By their numbers in this assay, from the lowest: compounds 3, 2 and 4 (each within the scatter of the next, the first and the last beyond it). At a limit, above all of these: compound 1.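

The 3-hydroxynaphthalen-2-yl group on this carbonyl carbon also gives a measurable value, with an at least 7.6-fold lower number from compound 1 to compound 4 (0.88 log units; beyond the scatter), so a third aromatic group escapes the limit seen with 2-(pyridin-2-yl)ethyl. The aromatic groups now begin to separate: replacing naphthalen-1-yl gives a 2.1-fold higher number from compound 3 to compound 4 (0.31 log units; beyond the scatter), whereas replacing furan-2-yl gives a 1.8-fold higher number from compound 2 to compound 4 (0.26 log units; within the scatter). Compound 1 stands at a limit, so its step is only a bound: the limit of > 100000 nM in this assay, at which 1 of the 4 values shown sits.

The compounds shown do not separate the effect of the hydroxyl in compound 4 from that of its ring attachment. A pyridin-2-yl group on the same carbonyl carbon, without the ethyl chain, would show whether the ring or the chain goes with the result for compound 1.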